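The compounds below may be only part of what the source reports. "The series", "measured", "known", "first", "only" and "open" are said of these compounds alone.

Of the compounds shown here, three from one series have been measured in a functional assay on MCF7 cells (Homo sapiens) for inhibition, read by MTT assay, with a stated time of 72 h; on this read-out lower numbers stand for stronger inhibition and higher numbers for weaker inhibition. Compound 1 `Cc1ccc(Nc2nc(SCc3cn(CC(=O)NC(=O)Nc4ccccn4)nn3)nc(-c3ccc(C(C)C)cc3)c2C#N)cc1` gives in this assay only > 64000 nM, which is a limit of the assay and not a number. Compound 2 `COc1cc(-c2nc(SCc3cn(CC(=O)NC(=O)Nc4ccccn4)nn3)nc(Nc3ccc(C(C)C)cc3)c2C#N)cc(OC)c1OC` gives in this assay 30900 nM. Compound 3 `Cc1ccc(Nc2nc(SCc3cn(CC(=O)NC(=O)Nc4ccccn4)nn3)nc(-c3ccc(Br)cc3)c2C#N)cc1` gives in this assay 14400 nM, the lowest of the two numbers shown, with compound 2 the nearest at a gap beyond the scatter. Within the data shown here, the only one-place step measured so far is an at least 4.4-fold lower number from compound 1 to compound 3 (0.64 log units; beyond the scatter), which concerns bromo in place of isopropyl on an aromatic carbon and not the amine side of the core.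

Compound 4 `CC(C)c1ccc(Nc2nc(SCc3cn(CC(=O)NC(=O)Nc4ccccn4)nn3)nc(-c3ccc(Br)cc3)c2C#N)cc1` differs from compound 3 by isopropyl in place of methyl on an aromatic carbon. Among the measured compounds shown here, no measured step changes this group on its own. For the measured compounds named here, compound 2 carries the same (4-isopropylphenyl)amino group but differs from compound 3 in two places, so its two values show only that compound 2 lies higher than compound 3. The expected step in this assay for compound 4 is therefore small, within the scatter and with its direction open, a 1.0-fold lower number from compound 3 to compound 4 (0.01 log units; within the scatter). Compound 4 is estimated at 14000 nM, expected to fall between 5000 nM and 40000 nM.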

Compound 4, half-maximal inhibitory concentration: 30600 nM
Estimate against measurement, compound 4: 2.2-fold (0.34 log units) below; measured number inside the range.
By their numbers in this assay, from the lowest: compound 3; then compounds 4 and 2 (each within the scatter of the next). At a limit, above all of these: compound 1.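

In this assay, among these compounds, the change from 4-methylphenyl to 4-isopropylphenyl gives the first one-place step on the amine side of the core, a 2.1-fold higher number from compound 3 to compound 4 (0.33 log units; beyond the scatter), so this group, para to a large group, does influence the read-out, and the two added carbons go with a modest loss of inhibition when 4-bromophenyl stays in place. With the (4-isopropylphenyl)amino group held constant, the step for 4-bromophenyl in place of 3,4,5-trimethoxyphenyl is a 1.0-fold lower number from compound 2 to compound 4 (0.00 log units; within the scatter), which shows that these two aromatic groups cannot be told apart in this setting, even though they differ widely in their substituents. Nothing measured here offers a reason for either step.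

The compounds shown leave open how the number responds to hydrogen, chlorine or methoxy in place of the methyl group on this ring, and whether a tert-butyl group would carry the trend further. From the compounds shown here alone, it also remains open whether the isopropyl step holds with 3,4,5-trimethoxyphenyl on the core, and what an amine or a carboxylic acid at this ring position would do.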